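Opening an Oxazolidinone Ring to a Simple Amine Chain

The compounds below may be only part of what the source reports. "The series", "measured", "known", "first", "only" and "open" are said of these compounds alone.

Three compounds share one core and are compared in a functional assay on HT cells (Homo sapiens) for antiproliferative activity, read by fluorescence, with a stated time of 72 h; on this read-out higher numbers stand for weaker inhibition of growth and lower numbers for stronger inhibition of growth. Compound 1 `CC(C)c1n[nH]c2c(NCc3ccc(-c4ccccn4)cc3)nc(SCCNC(=N)N)nc12` gives 390 nM in this assay, compound 2 `CSc1nc(NCc2ccc(-c3ccccn3)cc2)c2[nH]nc(C(C)C)c2n1` gives 783 nM, and compound 3 `CC(C)c1n[nH]c2c(NCc3ccc(-c4ccccn4)cc3)nc(SCC3CNC(=O)O3)nc12` gives 80 nM, the lowest of the three numbers, set apart from both others by steps beyond the scatter. The step of a 4.9-fold lower number from compound 1 to compound 3 (0.69 log units; beyond the scatter) and the step of a 9.8-fold lower number from compound 2 to compound 3 (0.99 log units; beyond the scatter) show how much the 2-oxo-1,3-oxazolidin-5-yl group adds over an amine-bearing chain or over hydrogen.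

Compound 4 `CNCCSc1nc(NCc2ccc(-c3ccccn3)cc2)c2[nH]nc(C(C)C)c2n1` is not yet measured. The change from compound 3 is (methylamino)methyl in place of 2-oxo-1,3-oxazolidin-5-yl on a saturated chain carbon bound to a sulfur. Its chain thus comes to resemble that of compound 1, which also carries a nitrogen-bearing chain on the carbon bound to sulfur. Since the step of a 4.9-fold lower number from compound 1 to compound 3 (0.69 log units; beyond the scatter) was modest and beyond the scatter, undoing the ring is expected to raise the number again, into the region of compound 1 and compound 2. Compound 4 is therefore estimated at 350 nM, within 120 nM to 1000 nM, an expected step of a 4.4-fold higher number from compound 3 to compound 4 (0.64 log units; beyond the scatter).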

Compound 4, concentration for 50% growth inhibition: 56 nM
For compound 4 the middle estimate is 6.3-fold (0.80 log units) above the measured one; measured number below the stated range.
By their numbers in this assay, from the lowest: compounds 4 and 3 (each within the scatter of the next); then compounds 1 and 2 (each within the scatter of the next).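

In this assay, the open (methylamino)methyl group on a saturated chain carbon bound to a sulfur does as well as the 2-oxo-1,3-oxazolidin-5-yl ring, with a 1.4-fold lower number from compound 3 to compound 4 (0.15 log units; within the scatter), so a low number at this position does not depend on that ring. The group also gives a 14-fold lower number from compound 2 to compound 4 (1.15 log units; beyond the scatter) against hydrogen, while one carbon atom in place of a larger group on an amine nitrogen gives a 7.0-fold lower number from compound 1 to compound 4 (0.84 log units; beyond the scatter), which shows that a nitrogen-bearing chain alone does not settle the number and that what the chain nitrogen carries matters. No measurement on hand explains these differences.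

The compounds shown leave open whether the chain nitrogen itself is required, a question that a primary amine or a hydroxyl group on the same chain would address. They also leave open whether a longer chain would keep the number as low.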